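A Phenoxy Group in Place of Cyclohexyl: Expected Cytotoxicity

This account rests on a few compounds, and the source may have more. Where it says the series, first, only, none or still open, it means among the compounds named here.

Measured so far in an ADME assay on HepG2 cells (Homo sapiens) for cytotoxicity, read by luminescence, CellTiter-Glo and ATP content, with a stated time of 72 h; on this read-out lower numbers stand for an effect already at smaller amounts and higher numbers for an effect only at larger amounts of compound:
Compound 1, `COc1ccc(F)cc1CNCCCNc1ccnc2cc(C3CCCCC3)ccc12`, gives 2290 nM.
Compound 2, `c1coc(CNCCCNc2ccnc3cc(CC4CCCCC4)ccc23)c1`, gives 1700 nM.
Compound 3, `c1coc(CNCCCNc2ccnc3cc(C4CCCCC4)ccc23)c1`, gives 4760 nM.

Among these three, compound 1 holds the second highest number in this assay. Compound 2 lies nearest to it, and the two values sit within the scatter of each other, so no order between compound 1 and compound 2 can be read from them. Compound 3 lies furthest from compound 1: the step of a 2.1-fold higher number from compound 1 to compound 3 (0.32 log units; beyond the scatter) goes beyond the scatter.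

The unmeasured compound 4, `COc1ccc(F)cc1CNCCCNc1ccnc2cc(Oc3cccc(N(C)C)c3)ccc12`, differs from compound 1 in one place: 3-(dimethylamino)phenoxy in place of cyclohexyl on an aromatic carbon.

Among the compounds with values here, none of the measured steps covers this exchange. Within the data shown here, the only change at the same aromatic carbon is a 2.8-fold higher number from compound 2 to compound 3 (0.45 log units; beyond the scatter), a modest step, and it exchanges two saturated groups rather than bringing in an aromatic ether. The step at the chain carbon, a 2.1-fold higher number from compound 1 to compound 3 (0.32 log units; beyond the scatter), is also modest and concerns another part of the core. Both suggest that single exchanges in this series have so far moved the number only modestly in this assay.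

On that basis the step of a 1.3-fold higher number from compound 1 to compound 4 (0.12 log units; within the scatter) is expected to stay small, with no clear direction. Compound 4 is therefore estimated at 3000 nM, with a range from 1000 nM to 9000 nM.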

Compound 4, half-maximal effective concentration: 3300 nM
The estimate for compound 4 lay 1.1-fold (0.04 log units) below the measured number, and the stated range covers the measured number.
By their numbers in this assay, from the lowest: compounds 2, 1, 4 and 3 (each within the scatter of the next, the first and the last beyond it).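

In this assay, the exchange of cyclohexyl for 3-(dimethylamino)phenoxy on this aromatic carbon gives a 1.4-fold higher number from compound 1 to compound 4 (0.16 log units; within the scatter), so a group with an aromatic ring, an ether link and 10 heavy atoms leaves the number indistinguishable from that of the saturated cyclohexyl group. Within the data shown here, the earlier compounds carried only saturated groups at this position, and their one step there, a 2.8-fold higher number from compound 2 to compound 3 (0.45 log units; beyond the scatter), went beyond the scatter even though it exchanged two closely related groups on a different side chain; the larger exchange in compound 4 shows that the size of a change at this carbon does not by itself set the size of the step. No available evidence accounts for this result.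

The compounds shown leave open how the parts of the new group contribute, since a plain phenoxy group, a phenyl group joined directly to the core or a morpholine at this carbon would be needed to separate the ether oxygen, the ring and the dimethylamino group. They also leave open whether 3-(dimethylamino)phenoxy would give a similar step in compounds carrying the furan-2-yl group on the side chain.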